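Trimming an Ether Side Chain on a Kinase Inhibitor

The source may report more compounds than this note shows. Statements on the series, on what has been measured and on what is new or still open speak of the compounds shown alone.

Of the compounds shown here, three have been tested in an assay on isolated protein for inhibition of Rho-associated protein kinase 2 (Homo sapiens) (a lower number here means a stronger inhibitor, a higher number a weaker inhibitor), and a fourth awaits its number. Compound 1 `CC(C)Oc1ccc2c(c1)CC(c1nc3ccc(-c4ccnc(N)n4)cc3[nH]1)CO2` gives 296 nM in this assay. Compound 2 `Cc1[nH]ncc1-c1ccc2nc(C3COc4ccccc4C3)oc2c1` gives 9 nM, and compound 3 `Cc1[nH]ncc1-c1ccc2nc(C3COc4ccccc4C3)[nH]c2c1` gives 9 nM. Among the three, compound 1 carries the highest number, and its gap to each of the other two lies beyond the usual scatter of repeated measurements, so it is the weakest inhibitor of the set. Compounds 2 and 3 are built on a different core from compound 1, so their values say little about how a small alteration to compound 1 will play out.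

Compound 4 `COc1ccc2c(c1)CC(c1nc3ccc(-c4ccnc(N)n4)cc3[nH]1)CO2` is compound 1 with a single alteration: methyl in place of isopropyl on an oxygen on an aromatic ring. The rings and the rest of the molecule stay as they are; only the chain on the oxygen is shortened from isopropoxy to methoxy. Among the measured compounds shown here, no measured pair shows a change of this kind, so there is nothing to lean on for direction. The expected step, a 1.0-fold higher number from compound 1 to compound 4 (0.01 log units; within the scatter), is taken to lie within the scatter, with no clear direction. Compound 4 is therefore estimated at 300 nM, likely between 100 nM and 900 nM.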

Compound 4, half-maximal inhibitory concentration: 2 nM
For compound 4 the middle estimate is 150-fold (2.18 log units) above the measured one, outside the stated range (below it).
By their numbers in this assay, from the lowest: compound 4; then compounds 2 and 3 (each within the scatter of the next); then compound 1.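

In this assay, among the compounds shown here, the shortening of isopropoxy to methoxy gives a 150-fold lower number from compound 1 to compound 4 (2.17 log units; beyond the scatter) and this is the first single-place change in the set, so it offers the first direct reading of this position. It shows that the chain on an oxygen on an aromatic ring is far from a neutral detail: with the rest of the molecule unchanged, replacing isopropyl with methyl, a change from three carbons to one, is enough to produce a large step well beyond the scatter. Nothing measured here bears on why the shorter chain gives so much stronger an inhibitor, so the pair establishes the direction and size of the step but no reason for it.

With only isopropoxy and methoxy shown at this place, the compounds leave open whether the number changes gradually or abruptly with chain size, and an ethoxy chain would sit usefully between these two. They also leave open how a free hydroxyl, a fluorine or a longer chain such as butoxy would compare on the same core.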